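Replacing the Chlorophenyl Group on a Shared Core

The source may hold more compounds than are shown below. What is called first, only, known or untested is meant among the compounds shown, and "the series" means these compounds.

Three compounds built on a shared core have been examined in an ADME assay on MT4 cells (Homo sapiens) for cytotoxicity, read by MTT assay, with a stated time of 4 days; a higher number here means that more compound is tolerated, a lower number that less compound is tolerated. Compound 1 `CNC(=O)Nc1c(C)c(C(OC(C)(C)C)C(=O)O)c(-c2ccc(C)c(C)c2)c(C)c1-c1ccc(C)c(C)c1` gives 20000 nM. Compound 2 `Cc1ccc(-c2c(C)c(-c3ccc(C)c(C)c3)c(C(OC(C)(C)C)C(=O)O)c(C)c2NC(=O)Nc2ccccc2)cc1C` gives 8000 nM, and the step of a 2.5-fold lower number from compound 1 to compound 2 (0.40 log units; beyond the scatter) comes from phenyl in place of methyl on an amide-type nitrogen. Compound 3 `Cc1ccc(-c2c(C)c(-c3ccc(Cl)cc3)c(C(OC(C)(C)C)C(=O)O)c(C)c2NS(C)(=O)=O)cc1C` gives 26000 nM, the highest of the three numbers; compound 1 is its nearest neighbour and lies within the scatter, while compound 2 is furthest away and lies beyond the scatter.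

Compound 4 `Cc1ccc(-c2c(C)c(-c3ccc4c(c3)CCO4)c(C(OC(C)(C)C)C(=O)O)c(C)c2NS(C)(=O)=O)cc1C` has not yet been measured in this assay. It differs from compound 3 by a group of 9 heavy atoms (8 carbon, 1 oxygen; one five-membered non-aromatic ring with 1 hetero atom, one six-membered aromatic ring of carbon only) in place of a group of 7 heavy atoms (6 carbon, 1 chlorine; one six-membered aromatic ring of carbon only), on an aromatic carbon. Going by the values given here, the only measured step, from compound 1 to compound 2, concerns a change on the amide-type nitrogen, not on the aromatic carbon where compound 4 differs, so no measured step bears directly on this change, and the two compounds that share the methanesulfonamido group offer no pair to compare. Among the compounds with values here, with no relevant precedent, the expected step from compound 3 to compound 4 is a 1.2-fold lower number from compound 3 to compound 4 (0.07 log units; within the scatter), that is, nothing beyond the scatter. Compound 4 is therefore estimated to give about 22000 nM, with a likely range from 9000 nM to 50000 nM.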

Compound 4, half-maximal cytotoxic concentration: 38000 nM
For compound 4 the middle estimate is 1.7-fold (0.24 log units) below the measured one; the range from low to high includes it.
By their numbers in this assay, from the lowest: compound 2; then compounds 1, 3 and 4 (each within the scatter of the next).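

In this assay, going by these compounds alone, this is the first measured change on the aromatic carbon para to the methanesulfonamido group, as the only earlier step concerned the amide-type nitrogen. Putting the group of 9 heavy atoms, with its five-membered non-aromatic ring and 1 hydrogen-bond acceptor, in place of 4-chlorophenyl gives a 1.5-fold higher number from compound 3 to compound 4 (0.16 log units; within the scatter), so this read-out does not separate the two groups, even though the swap adds a ring and an oxygen and removes the chlorine. No measurement shown here accounts for the result, and nothing can be said about what lies behind it.

The compounds shown leave open whether any group at this carbon would move the number beyond the scatter, for instance a phenyl ring carrying an amine or a carboxylic acid, or a pyridine ring, since this single pair covers only two neutral aromatic groups. They also leave open whether the same replacement would behave alike on a compound with a different group on the nitrogen, such as the phenyl-bearing urea of compound 2, whose number is the lowest of the set.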